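Triazole aryl swap: dichlorophenyl after dimethylphenyl

The source may report more compounds than this note shows. Statements on the series, on what has been measured and on what is new or still open speak of the compounds shown alone.

Measured compounds:
compound 1, `COc1cc2c(Oc3ccc(NC(=O)c4cn(-c5ccccc5F)nn4)cc3F)ccnc2cc1OCCCN1CCC(C)CC1`, 190 nM
compound 2, `COc1cc2c(Oc3ccc(NC(=O)c4cn(-c5c(C)cccc5C)nn4)cc3F)ccnc2cc1OCCCN1CCC(C)CC1`, 2360 nM

Compound 2 carries the 2,6-dimethylphenyl group on the triazole nitrogen of the shared core. In a functional assay on NCI-H460 cells (Homo sapiens) for cytotoxicity, read by MTT assay, with a stated time of 72 h (a higher number here means a weaker inhibitor, a lower number a stronger inhibitor), compound 2 gives the higher of the two numbers, standing apart from compound 1 by a 12-fold higher number from compound 1 to compound 2 (1.09 log units; beyond the scatter), a large step. Compound 3, `COc1cc2c(Oc3ccc(NC(=O)c4cn(-c5c(Cl)cccc5Cl)nn4)cc3F)ccnc2cc1OCCCN1CCC(C)CC1`, is not yet measured. It differs from compound 2 in one place: 2,6-dichlorophenyl in place of 2,6-dimethylphenyl on an aromatic nitrogen.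

Going by the values given here, only one measured step bears on this change. The step of a 12-fold higher number from compound 1 to compound 2 (1.09 log units; beyond the scatter) shows that the choice of aryl group on that nitrogen can move this assay by a large amount, but it compares a 2-fluorophenyl with a 2,6-dimethylphenyl, not a 2,6-dimethylphenyl with a 2,6-dichlorophenyl. Both compound 2 and compound 3 keep the same 2,6-substitution pattern. Among the compounds with values here, no measured pair isolates the methyl-to-chlorine exchange.

Given that uncertainty, compound 3 is expected to stay near compound 2, with a modest step of a 1.6-fold lower number from compound 2 to compound 3 (0.20 log units; within the scatter) toward a lower number and a wide range. The estimate for compound 3 in this assay is 1500 nM, with a range from 400 nM to 5000 nM.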

Compound 3, half-maximal inhibitory concentration: 270 nM
The estimate for compound 3 lay 5.6-fold (0.74 log units) above the measured number; the whole stated range lies above it.
By their numbers in this assay, from the lowest: compounds 1 and 3 (each within the scatter of the next); then compound 2.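

In this assay the exchange of 2,6-dimethylphenyl for 2,6-dichlorophenyl on the aromatic nitrogen gives an 8.7-fold lower number from compound 2 to compound 3 (0.94 log units; beyond the scatter) and so shows that two aryl groups with the same 2,6-substitution pattern and the same count of heavy atoms are not interchangeable at this position. The comparison with the 2-fluorophenyl group gives a 1.4-fold higher number from compound 1 to compound 3 (0.15 log units; within the scatter) and places compound 3 level with compound 1, so among these three compounds the 2,6-substitution pattern alone does not go with the higher number, and only the 2,6-dimethylphenyl group of compound 2 stands apart. Nothing measured here explains why the methyl and chlorine versions differ. The compounds shown leave open whether a 2,6-difluorophenyl or a 2,6-dimethoxyphenyl group on the same nitrogen would fall with compound 1 and compound 3 or with compound 2. They also leave open whether a single chlorine or a single methyl on that phenyl ring would give a number closer to that of compound 1 or to that of compound 2.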